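The compounds below may be only part of what the source reports. "The series", "measured", "known", "first", "only" and "open" are said of these compounds alone.

In a physicochemical assay for solubility, using the shake flask method, in simulated intestinal fluid, measured as kinetic solubility, with a stated time of 2 h, at 25 degrees C, at pH 6.5 (a higher number here means a more soluble compound, a lower number a less soluble compound), compound 1 (`Cc1noc(-c2nc(C)c3c(c2N)C(=O)N(Cc2ccccc2)C3=O)n1`) gives < 5000 nM, which is a limit of the assay and not a number. Compound 2 (`Cc1noc(-c2nc(C)c3c(c2N)C(=O)N(Cc2ccccc2Cl)C3=O)n1`) gives < 5000 nM, which is also only a limit, so its standing is bounded rather than measured. The evidence amounts to the limit of < 5000 nM in this assay, at which 2 of the 2 values shown sit. Compound 3 (`Cc1noc(-c2nc(C)c3c(c2N)C(=O)N(Cc2ccccc2C(F)(F)F)C3=O)n1`) has trifluoromethyl in place of chloro on an aromatic carbon, ortho to a large group: trifluoromethyl in place of chloro on an aromatic carbon. Within the data shown here, only one measured step bears on this change, a step that the two limits leave unreadable from compound 1 to compound 2, and it offers no size to carry forward. No step beyond the scatter is therefore expected in this assay, and no direction can be assigned. The expected step is a step that the limit leaves unreadable from compound 2 to compound 3. For compound 3, the estimated solubility is 2500 nM, with an expected range of 700 nM to 5000 nM, and the assay may well report only a limit again.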

Compound 3, solubility: < 5000 nM
Compound 3 was reported as a limit; the forecaster's own chance of this, stated with the estimate: 85%; the middle value lies beyond the limit too.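

In this assay compound 3 gives < 5000 nM, which is again a limit and not a number. Among these compounds, no step between compound 1, compound 2 and compound 3 can be read. The compounds shown leave open how hydrogen, chloro and trifluoromethyl on this aromatic carbon compare, with all of them resting on one value: the limit of < 5000 nM in this assay, at which 3 of the 3 values shown sit.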